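A few compounds are considered here, and "the series" means these few. Any claim that something is new, unique, unknown or untested is made for them only; others in the source may bear on it.

Within the data shown here, in an assay on mitochondria (strain Sprague-Dawley) for inhibition of Amine oxidase [flavin-containing] B (Rattus norvegicus), read by fluorescence and Amplex Red, with stated times of 30 min and 45 min (a lower number here means a stronger inhibitor, a higher number a weaker inhibitor), three compounds have numbers so far. Compound 1 `COc1cccc(CCCC(=O)Nc2nc3ccccc3c(=O)s2)c1` gives 1300 nM in this assay. Compound 2 `Cc1sc2nc(NC(=O)CCCc3ccccc3)sc(=O)c2c1C` gives 26.6 nM in this assay. Compound 3 `O=C(CCCc1ccccc1)Nc1nc2ccc(Cl)cc2c(=O)s1` reaches only a limit of this assay, > 10000 nM, so no number is known for it. Compound 3 sits at the limit of > 10000 nM in this assay, at which 1 of the 3 values shown sits. Among the two real numbers, compound 1 stands highest, and its nearest neighbour is compound 2, whose lower value lies well beyond the usual scatter.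

Compound 4 `O=C(CCCc1cccc(Cl)c1)Nc1nc2ccccc2c(=O)s1` has not been measured. It differs from compound 1 in a single place: chloro in place of methoxy on an aromatic carbon. Cut one bond further out, 3-methoxyphenyl becomes 3-chlorophenyl, with everything else unchanged. Among the measured compounds shown here, no measured pair differs in exactly this way, so the size of the step is open. Because compound 1 gives 1300 nM with a change only on an aromatic carbon of a six-membered aromatic ring of carbon only, the step of a 1.3-fold lower number from compound 1 to compound 4 (0.11 log units; within the scatter) is expected to be small, within or near the scatter, in either direction. Compound 4 is estimated at 1000 nM in this assay, with a likely range from 300 nM to 4000 nM.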

Compound 4, half-maximal inhibitory concentration: 6880 nM
Estimate against measurement, compound 4: 6.9-fold (0.84 log units) below; measured number outside the range, above it.
By their numbers in this assay, from the lowest: compound 2; then compound 1; then compound 4. At a limit, above all of these: compound 3.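

Among these compounds, this is the first pair that differs in only one place, and it shows that the group on this aromatic carbon, meta to a large group, matters: in this assay the change of 3-methoxyphenyl to 3-chlorophenyl gives a 5.3-fold higher number from compound 1 to compound 4 (0.72 log units; beyond the scatter) on an otherwise unchanged molecule. Of these two groups, methoxy goes with the stronger inhibitor on this core, so this place is not free to change without cost. Nothing measured among these compounds explains why the chloro compound is weaker.

The compounds shown leave open how a plain hydrogen, a fluoro, a hydroxyl or an amine at this place would compare with methoxy and chloro. A single pair also cannot tell whether the same change would have a similar effect on a different core.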